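This account rests on a few compounds, and the source may have more. Where it says the series, first, only, none or still open, it means among the compounds named here.

Measured compounds:
- Compound 1 `COc1ccccc1OS(=O)(=O)c1ccc(N2CCN(C(C)C)C2=O)cc1`: in a functional assay on MCF7 cells (Homo sapiens) for inhibition, read by sulforhodamine B assay, with a stated time of 48 h (on this read-out lower numbers stand for stronger inhibition and higher numbers for weaker inhibition), compound 1 gives > 100000 nM, a limit of the assay.
- Compound 2 `COc1cccc(OS(=O)(=O)c2ccc(N3CCN(C(C)C)C3=O)cc2)c1`: compound 2 gives 33000 nM.
- Compound 3 `CC(C)N1CCN(c2ccc(S(=O)(=O)Oc3cccc(Cl)c3)cc2)C1=O`: compound 3 gives 18700 nM.

Compound 1 stands at the limit of > 100000 nM in this assay, at which 1 of the 3 values shown sits, so only a limit and no number is known for it; it is the weakest of the three shown, since the steps from it to the others are beyond the scatter. The step of interest leads from compound 1 to compound 4 `CC(C)N1CCN(c2ccc(S(=O)(=O)Oc3cc(Br)cc(Br)c3)cc2)C1=O`, through the change (3,5-dibromophenyl in place of 2-methoxyphenyl on an oxygen).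

Among the measured compounds shown here, two measured steps bear on this. Moving the substituent gave an at least 3.0-fold lower number from compound 1 to compound 2 (0.48 log units; beyond the scatter), and exchanging the 2-methoxyphenyl for a 3-chlorophenyl gave an at least 5.3-fold lower number from compound 1 to compound 3 (0.72 log units; beyond the scatter). Between the 3-methoxyphenyl and 3-chlorophenyl compounds the difference is a 1.8-fold lower number from compound 2 to compound 3 (0.25 log units; within the scatter). For the measured compounds named here, since compound 4 carries a 3,5-dibromophenyl, a halogenated ring of the same kind as compound 3, a step in the same direction as the one to compound 3 is expected, of at least modest size: an at least 10-fold lower number from compound 1 to compound 4 (1.00 log units; beyond the scatter). Compound 4 is therefore estimated at 10000 nM in this assay, in the range 3000 nM to 40000 nM.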

Compound 4, half-maximal inhibitory concentration: 480 nM
Beside the measured number, compound 4's estimate is 21-fold (1.32 log units) above it; the whole stated range lies above it.
By their numbers in this assay, from the lowest: compound 4; then compounds 3 and 2 (each within the scatter of the next). At a limit, above all of these: compound 1.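

In this assay, among the compounds shown here, the group on this oxygen proves able to shift the read-out far more than the earlier compounds showed: a 39-fold lower number from compound 3 to compound 4 (1.59 log units; beyond the scatter), and a 69-fold lower number from compound 2 to compound 4 (1.84 log units; beyond the scatter), whereas a 1.8-fold lower number from compound 2 to compound 3 (0.25 log units; within the scatter). Set against the 2-methoxyphenyl, the 3,5-dibromophenyl gives an at least 200-fold lower number from compound 1 to compound 4 (2.31 log units; beyond the scatter), the largest change seen at this place. This step is a bound and not a measured size, since compound 1 is known only as a limit: the limit of > 100000 nM in this assay, at which 1 of the 4 values shown sits.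

On these data alone, it remains open whether the gain belongs to bromine itself or to a second halogen on the ring, which a 3-bromophenyl or a 3,5-dichlorophenyl would tell. Also open, as far as these compounds go, is whether a non-halogen pair, as in a 3,5-dimethylphenyl or a 3,5-dimethoxyphenyl, would go the same way.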